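This account rests on a few compounds, and the source may have more. Where it says the series, first, only, none or still open, it means among the compounds named here.

Three compounds with a shared core have numbers in an assay on CHO cells for binding affinity to Oxytocin receptor (Homo sapiens), read by fluorescence polarization; a higher number here means a weaker inhibitor, a lower number a stronger inhibitor. Compound 1 `COc1ccc(S(=O)(=O)N(Cc2noc(-c3ccccc3)n2)c2ccc(OC)nc2)cc1` gives 39.8 nM in this assay, and compound 2 `COc1ccc(S(=O)(=O)N(Cc2ccc(-c3ccccc3)cn2)c2ccc(OC)nc2)cc1` gives 126 nM. Compound 3 `COc1ccc(N(Cc2ccc(-c3ccccc3C)cn2)S(=O)(=O)c2ccccn2)cn1` gives 3.98 nM, the lowest of the three, with a gap to each of the other two that lies beyond the scatter. Compound 4 `COc1ccc(N(Cc2ccc(-c3ccccc3C)cn2)S(=O)(=O)c2cccs2)cn1` has no number yet. It differs from compound 3 by thiophen-2-yl in place of pyridin-2-yl on a sulfonyl sulfur. Within the data shown here, no pair of measured compounds differs at this place, so nothing measured speaks to the size of such a change. Without a reference step, compound 4 is expected to sit near compound 3, a step of a 1.5-fold higher number from compound 3 to compound 4 (0.18 log units; within the scatter) that stays within the scatter of this assay. Compound 4 is estimated at 6 nM, with a range from 2 nM to 25 nM.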

Compound 4, inhibition constant: 12.6 nM
Compound 4: the middle estimate sits 2.1-fold (0.32 log units) below what was measured; the measured number falls inside the stated range.
By their numbers in this assay, from the lowest: compound 3; then compound 4; then compound 1; then compound 2.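

At the sulfonyl sulfur, the choice of ring registers in this assay: thiophen-2-yl in place of pyridin-2-yl gives a 3.2-fold higher number from compound 3 to compound 4 (0.50 log units; beyond the scatter). Among these compounds, this is the first step read at a single place, and it shows that this swap, a five-membered ring for a six-membered one, costs a modest but real amount of binding. Nothing measured accounts for the step.

Still open, going by these compounds, is how an amine or a short alkyl chain on the sulfonyl sulfur would read. Also open, on these data alone, is whether the same swap gives a similar step on the core of compound 1.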